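A smaller group on the sulfur of compound 2

The source may report more compounds than this note shows. Statements on the series, on what has been measured and on what is new or still open speak of the compounds shown alone.

Values measured so far in a functional assay on ECa-109 cells for antiproliferative activity against ECa-109 cell line (Homo sapiens), read by MTT assay, with a stated time of 48 h (on this read-out higher numbers stand for weaker inhibition and lower numbers for stronger inhibition), are these:
- compound 1 `COc1ccc(CN(C(=O)CSc2ccccn2)c2cc(OC)c(OC)c(OC)c2)cc1` gives 16000 nM here
- compound 2 `COc1ccc(CN(C(=O)CSc2nc3ccc(OC)cc3s2)c2cc(OC)c(OC)c(OC)c2)cc1` gives > 80000 nM as a limit, not a number
- compound 3 `COc1ccc(CN(C(=O)CCCCSc2nc3ccccc3o2)c2cc(OC)c(OC)c(OC)c2)cc1` gives 7650 nM here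

Compound 2 has only a limit in this assay rather than a number (the limit of > 80000 nM in this assay, at which 1 of the 3 values shown sits) and so cannot be placed exactly.

In compound 4 `COc1ccc(CN(C(=O)CSc2nnnn2C)c2cc(OC)c(OC)c(OC)c2)cc1` the 1-methyl-1H-tetrazol-5-yl group replaces 6-methoxy-1,3-benzothiazol-2-yl on a sulfur (1-methyl-1H-tetrazol-5-yl in place of 6-methoxy-1,3-benzothiazol-2-yl on a sulfur) and the rest stays the same.

Among the compounds with values here, one measured step bears on this change: an at least 5.0-fold higher number from compound 1 to compound 2 (0.69 log units; beyond the scatter), made at the same place, starting from pyridin-2-yl. Within the data shown here, compound 3 differs in more than one place and offers no direct step.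

Compound 4 gives up the group that came with that rise, so a move toward lower numbers in this assay is expected, roughly back toward compound 1 at 16000 nM in this assay. A tetrazole is not a pyridine, however, so the size is uncertain.

The expected change on this estimate is an at least 3.2-fold lower number from compound 2 to compound 4 (0.50 log units; beyond the scatter) in this assay.

For compound 4 the estimated value is 25000 nM, with an expected range from 9000 nM to 70000 nM in this assay.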

Compound 4, half-maximal inhibitory concentration: 5540 nM
Estimate against measurement, compound 4: 4.5-fold (0.65 log units) above; the whole stated range lies above it.
By their numbers in this assay, from the lowest: compounds 4 and 3 (each within the scatter of the next); then compound 1. At a limit, above all of these: compound 2.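

Compound 2 has only a limit, not a number, in this assay: the limit of > 80000 nM in this assay, at which 1 of the 4 values shown sits.

Placing 1-methyl-1H-tetrazol-5-yl on the sulfur gives an at least 14-fold lower number from compound 2 to compound 4 (1.15 log units; beyond the scatter), and the true size of this step may be larger still. The same group also gives a 2.9-fold lower number from compound 1 to compound 4 (0.46 log units; beyond the scatter), so this change does more than undo the loss seen with 6-methoxy-1,3-benzothiazol-2-yl: the position can carry a group that takes the number below the one set by pyridin-2-yl.

The compounds shown do not tell whether this gain depends on the tetrazole ring as a whole or on its methyl, which a phenyl or an amine in that place would help to separate. Also open, on these data alone, is how 1-methyl-1H-tetrazol-5-yl would behave on a longer chain.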